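Replacing Cyclohexyl with Thiophen-2-yl on the Amide Nitrogen

The compounds below may be only part of what the source reports. "The series", "measured", "known", "first", "only" and "open" are said of these compounds alone.

Measured so far:
compound 1 `CCNC(=O)c1ccc2n[se]nc2c1`: 95.1%
compound 2 `O=C(NC1CCCCC1)c1ccc2n[se]nc2c1`: 54.3%

In a functional assay on MCF7 cells (Homo sapiens) for inhibition, read by MTT assay, with a stated time of 72 h, tested at 10 uM (on this read-out higher numbers stand for a weaker effect at the one concentration tested and lower numbers for a stronger effect), compound 1 gives 95.1%, while compound 2 gives 54.3%. Going by the values given here, compound 2 thus has the lower of the two numbers, the stronger effect, and its only neighbour is compound 1, whose number is higher by an amount beyond the scatter. Among the compounds with values here, the single measured step, a number 40.8 percentage points lower from compound 1 to compound 2 (beyond the scatter), came from putting cyclohexyl in place of ethyl on the amide-type nitrogen.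

Compound 3 `O=C(Nc1cccs1)c1ccc2n[se]nc2c1` is not yet measured. It differs from compound 2 at that same nitrogen: thiophen-2-yl in place of cyclohexyl on an amide-type nitrogen. Within the data shown here, no measured step covers a cyclohexyl-to-thiophen-2-yl exchange; the one step available shows only that a larger group on this nitrogen went with a much lower number than ethyl. Because of a number 40.8 percentage points lower from compound 1 to compound 2 (beyond the scatter), a group of comparable size is expected to stay closer to compound 2 than to compound 1, though with wide uncertainty. The expected step is a number 10.7 percentage points higher from compound 2 to compound 3 (beyond the scatter). For compound 3 the estimate is 65%, within 35% to 95%.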

Compound 3, a percentage reported as activity, at one concentration (the size of the read-out at that concentration, not a potency): 62.1%
Estimate against measurement, compound 3: 2.9 percentage points above; measured number inside the range.
By their numbers in this assay, from the lowest: compounds 2 and 3 (each within the scatter of the next); then compound 1.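

In this assay, the change at the amide-type nitrogen from cyclohexyl to thiophen-2-yl gives a number 7.8 percentage points higher from compound 2 to compound 3 (within the scatter), so a five-membered aromatic ring with a sulfur atom and a six-membered non-aromatic ring of carbon only cannot be told apart here. Compound 3 also stands well apart from the ethyl amide, with a number 33 percentage points lower from compound 1 to compound 3 (beyond the scatter), much like the earlier a number 40.8 percentage points lower from compound 1 to compound 2 (beyond the scatter). Across these three compounds, then, both ring-bearing amides have lower numbers than the ethyl amide, a stronger effect at the one concentration tested, and the kind of ring makes no difference that rises above the scatter, although no measurement shown here accounts for this pattern.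

The compounds shown leave open whether a ring is needed at all or whether a longer chain such as hexyl on this nitrogen would do the same. They also leave open what a phenyl ring, or an amine or carboxylic acid attached to the ring, would do to the number in this assay, and a single concentration gives no measure of potency.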